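From Fluoro to Chloro in a Small Series

A few compounds are considered here, and "the series" means these few. Any claim that something is new, unique, unknown or untested is made for them only; others in the source may bear on it.

For the measured compounds named here, two close relatives have numbers so far. In a functional assay on P388 cells (Mus musculus) for inhibition (a lower number here means a stronger inhibitor, a higher number a weaker inhibitor), compound 1 `O=C1/C(=C/c2ccc(F)cc2)CCCc2ccccc21` gives 11100 nM as its result, and compound 2 `O=C1/C(=C/c2cccc(Cl)c2)CCCc2ccccc21` gives 8200 nM as its result. These two numbers lie within the usual scatter of repeated measurements, so compound 1 cannot be ranked apart from compound 2. Compound 3 `O=C1/C(=C/c2ccc(Cl)cc2)CCCc2ccccc21` has not been measured yet. It comes from compound 1 by one small edit: chloro in place of fluoro on an aromatic carbon, para to a large group. Going by the values given here, no measured pair shows this exact swap, so the data offer no direct guide. Compound 2, with 8200 nM as its value, does carry a chloro group and still sits level with compound 1, so no step beyond the scatter is expected in this assay for this edit. The estimate means a 1.4-fold lower number from compound 1 to compound 3 (0.14 log units; within the scatter) as the expected step, which is small and leans only slightly toward compound 2. For compound 3 the expected value is 8000 nM, with an estimated range from 3500 nM to 18000 nM for a single measurement.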

Compound 3, half-maximal inhibitory concentration: 9500 nM
Beside the measured number, compound 3's estimate is 1.2-fold (0.07 log units) below it; the measured number falls inside the stated range.
By their numbers in this assay, from the lowest: compounds 2, 3 and 1 (each within the scatter of the next).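

In this assay, for the compounds shown here, the direct swap of fluoro for chloro on an aromatic carbon, para to a large group, amounts to a 1.2-fold lower number from compound 1 to compound 3 (0.07 log units; within the scatter) and so gives the first direct reading of this edit on the shared core. At this position, then, exchanging one halogen for the other leaves the result indistinguishable from that of compound 1, and compound 3 at 9500 nM also stays level with compound 2 at 8200 nM, which carries its chloro group at a different place on the ring. Nothing among the available measurements offers an explanation for this flat result.

As far as these compounds go, all three compounds carry a single halogen on this aromatic ring, so it remains open whether a group of another kind in this place, such as a methoxy group, an amine or a carboxylic acid, would move the number beyond the scatter. The compounds also leave open whether changes elsewhere on the shared core would matter more than this exchange of halogens.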